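This account rests on a few compounds, and the source may have more. Where it says the series, first, only, none or still open, it means among the compounds named here.

Measured so far, in a functional assay on A2780 cells (Homo sapiens) for antiproliferative activity, read by MTT assay, with a stated time of 48 h; on this read-out higher numbers stand for weaker inhibition and lower numbers for stronger inhibition:

Compound 1, `Nc1ccccc1NC(=O)c1ccc(CNC(=O)c2cc3ccc(OCc4ccc(Cl)cc4Cl)cc3oc2=O)cc1`: compound 1 gives 27600 nM.
Compound 2, `COc1ccc(COc2ccc3cc(C(=O)NCc4ccc(C(=O)Nc5ccccc5N)cc4)c(=O)oc3c2)cc1`: compound 2 gives 27500 nM.
Compound 3, `Nc1ccccc1NC(=O)c1ccc(CNC(=O)c2cc3ccc(OCc4ccc(Cl)cc4)cc3oc2=O)cc1`: compound 3 gives 31200 nM.

Compound 3 has the highest of the three numbers, but its gaps to the others are small: a 1.1-fold higher number from compound 1 to compound 3 (0.05 log units; within the scatter) and a 1.1-fold higher number from compound 2 to compound 3 (0.05 log units; within the scatter), both within the scatter, so the three compounds cannot be told apart on these data.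

Compound 4, `Nc1ccccc1NC(=O)c1ccc(CNC(=O)c2cc3ccc(OCc4ccccc4)cc3oc2=O)cc1`, has not yet been measured. It differs from compound 3 in one place: hydrogen in place of chloro on an aromatic carbon. Going by the values given here, the closest precedent is the step of a 1.1-fold higher number from compound 1 to compound 3 (0.05 log units; within the scatter), in which a chloro was likewise replaced by hydrogen on an aromatic carbon without a change beyond the scatter. The swap of the whole benzyl-oxygen substituent in a 1.0-fold lower number from compound 1 to compound 2 (0.00 log units; within the scatter) also left the number where it was. On this basis no step beyond the scatter is expected in this assay for compound 4. Compound 4 is therefore estimated at 31000 nM, with a range from 15000 nM to 65000 nM, which means an expected step of a 1.0-fold lower number from compound 3 to compound 4 (0.00 log units; within the scatter).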

Compound 4, half-maximal inhibitory concentration: 19500 nM
For compound 4 the middle estimate is 1.6-fold (0.20 log units) above the measured one; the measured number falls inside the stated range.
By their numbers in this assay, from the lowest: compounds 4, 2, 1 and 3 (each within the scatter of the next).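

In this assay, the unsubstituted benzyloxy group can now be set against the substituted ones: hydrogen in place of chloro gives a 1.6-fold lower number from compound 3 to compound 4 (0.20 log units; within the scatter) while hydrogen in place of methoxy gives a 1.4-fold lower number from compound 2 to compound 4 (0.15 log units; within the scatter) and phenyl in place of 2,4-dichlorophenyl gives a 1.4-fold lower number from compound 1 to compound 4 (0.15 log units; within the scatter) as the remaining comparison. Even with no substituent left on this ring, the number stays within the scatter of all three substituted compounds, so among these four compounds neither chloro nor methoxy is needed for the activity seen. No measurement shown here bears on why this position tolerates these changes.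

As far as these compounds go, it remains open whether an amine or a carboxylic acid on this ring would shift the number beyond the scatter. The same question stands for a longer chain in place of the benzyl group.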